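The source may hold more compounds than are shown below. What is called first, only, known or untested is meant among the compounds shown, and "the series" means these compounds.

Compound 3, `CC1(C)CC(OC(=O)CN2CN(c3ccccc3)C3(CCN(C(=O)c4ccc(C(C)(C)C)cc4)CC3)C2=O)CC(C)(C)N1`, gives 1300 nM in an assay on HEK293 cells for displacement of a labelled ligand from NPC1-like intracellular cholesterol transporter 1 (Homo sapiens); a higher number here means a weaker inhibitor, a lower number a stronger inhibitor. Its number sits close to those of the two other compounds measured in this assay: compound 1, `O=C(CN1CN(c2ccccc2)C2(CCN(C(=O)c3ccc(C4CCCCC4)cc3)CC2)C1=O)N1CCC(CO)CC1`, gives 1100 nM, and compound 2, `CC(C)(C)OC(=O)NCNC(=O)CN1CN(c2ccccc2)C2(CCN(C(=O)c3ccc(C4CCCCC4)cc3)CC2)C1=O`, gives 1700 nM, and all three lie within the usual scatter of one another, so none can be called stronger or weaker than the rest.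

Compound 4, `CCOC(=O)C1CCCN(C(=O)CN2CN(c3ccccc3)C3(CCN(C(=O)c4ccc(C(C)(C)C)cc4)CC3)C2=O)C1`, differs from compound 3 in one place: 3-(ethoxycarbonyl)piperidin-1-yl in place of (2,2,6,6-tetramethylpiperidin-4-yl)oxy on a carbonyl carbon. Among the measured compounds shown here, one measured step bears on this kind of change, since it also swaps the group on that carbonyl carbon: a 1.5-fold higher number from compound 1 to compound 2 (0.19 log units; within the scatter), which stayed within the scatter. For the measured compounds named here, only that single step is available, and it comes from a pair carrying a different group on the benzoyl ring, so the guidance is thin. On this evidence the step from compound 3 to compound 4 is expected to be small, with no clear direction, estimated as no change at the digits printed from compound 3 to compound 4 (within the scatter).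

Compound 4 is therefore estimated at 1300 nM in this assay, with a likely range from 600 nM to 3000 nM.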

Compound 4, half-maximal inhibitory concentration: 8200 nM
For compound 4 the middle estimate is 6.3-fold (0.80 log units) below the measured one, and the stated range ends below it.
By their numbers in this assay, from the lowest: compounds 1, 3 and 2 (each within the scatter of the next); then compound 4.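

Among the compounds shown here, on the carbonyl carbon, the group can matter in this assay: replacing (2,2,6,6-tetramethylpiperidin-4-yl)oxy with 3-(ethoxycarbonyl)piperidin-1-yl gives a 6.3-fold higher number from compound 3 to compound 4 (0.80 log units; beyond the scatter) and so a weaker inhibitor, whereas the one earlier step at this place, a 1.5-fold higher number from compound 1 to compound 2 (0.19 log units; within the scatter), stayed within the scatter. This change is not one of heavy-atom count or ring type, since both groups have 11 heavy atoms and one six-membered non-aromatic ring with 1 hetero atom, but the group that enters brings a double bond outside aromatic rings and has no hydrogen-bond donor, while the group that leaves has one. Nothing measured here shows which of these differences lies behind the step.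

The compounds shown leave open whether the ethoxycarbonyl group or the change in the ring and its link to the carbonyl carbon accounts for the step. A plain piperidin-1-yl group, or a carboxylic acid in place of the ethyl ester on the same ring, would help to separate these two possibilities.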